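Replacing 5-chloro-1-benzothiophen-3-yl with benzyl on the sulfur chain

The compounds below may be only part of what the source reports. "The series", "measured", "known", "first", "only" and "open" are said of these compounds alone.

Going by the values given here, in a functional assay on BGC-823 cells (Homo sapiens) for inhibition, read by MTT assay, with a stated time of 72 h (a lower number here means a stronger inhibitor, a higher number a weaker inhibitor), compound 1 (`Cc1cc(N2CC[C@@H](C)[C@@H](N(C)c3ncnc4[nH]ccc34)C2)n2nc(SCc3ccccc3)nc2n1`) gives 14400 nM, the only true number in this small set. Compound 2 (`Cc1cc(N2CC[C@@H](C)[C@@H](N(C)c3ncnc4[nH]ccc34)C2)n2nc(SCc3nc4ccccc4[nH]3)nc2n1`) reads > 100000 nM, which is a limit of the assay. Compound 3 (`Cc1cc(N2CC[C@@H](C)[C@@H](N(C)c3ncnc4[nH]ccc34)C2)n2nc(SCc3csc4ccc(Cl)cc34)nc2n1`) reads > 100000 nM, also a limit and not a number, so its standing is known only as a bound, shared with compound 2.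

Compound 4 (`Cc1cc(N2CC[C@@H](C)[C@@H](N(C)c3ncnc4[nH]ccc34)C2)n2nc(SCCc3ccccc3)nc2n1`) has benzyl in place of 5-chloro-1-benzothiophen-3-yl on a saturated chain carbon bound to a sulfur. The closest measured evidence is the reverse kind of exchange, an at least 6.9-fold higher number from compound 1 to compound 3 (0.84 log units; beyond the scatter), where the phenyl of compound 1 gave way to the same group. The step of an at least 6.9-fold higher number from compound 1 to compound 2 (0.84 log units; beyond the scatter) points the same way, while a step that the two limits leave unreadable from compound 2 to compound 3 adds nothing. Compound 4 again ends in a carbon-only aromatic ring, as compound 1 does at 14400 nM, so a return towards that level is the reasonable expectation. On these data alone, the longer chain is untested, though, and compound 4 could stay at the limit. The expected change is a move to a lower number, estimated as an at least 5.0-fold lower number from compound 3 to compound 4 (0.69 log units; beyond the scatter). Compound 4 is expected at 20000 nM, with an estimated range of 6000 nM to 80000 nM.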

Compound 4, half-maximal inhibitory concentration: 28000 nM
For compound 4 the middle estimate is 1.4-fold (0.15 log units) below the measured one; measured number inside the range.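

With a phenethyl group on the sulfur, a true number returns in this assay, and both steps away from the limit lie beyond the scatter: an at least 3.5-fold lower number from compound 3 to compound 4 (0.55 log units; beyond the scatter), and an at least 3.5-fold lower number from compound 2 to compound 4 (0.55 log units; beyond the scatter). The earlier compounds shown here could not show how the chain length at this place counts, and here a 1.9-fold higher number from compound 1 to compound 4 (0.29 log units; within the scatter), so compound 1 and compound 4 cannot be told apart in this assay. Among the four compounds, the two ending in a plain phenyl ring give true numbers, while the 1H-benzimidazol-2-yl and 5-chloro-1-benzothiophen-3-yl compounds stay at a limit and not at a number: the limit of > 100000 nM in this assay, at which 2 of the 4 values shown sit.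

On these data alone, how far compound 2 and compound 3 lie past that limit remains unknown, and the step between them cannot be read. Also open, as far as these compounds go, is whether a methoxy group or a fluorine on the phenyl ring, an amine at the end of the chain, or a chain longer than phenethyl would bring the number lower than compound 1 and compound 4 reach.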